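Solubility after swapping a lactam ring for an open amide

The source may hold more compounds than are shown below. What is called first, only, known or untested is meant among the compounds shown, and "the series" means these compounds.

Compound 1 `CN(c1ccn(C)n1)c1cnc(NCc2c(F)ccc3c2CCO3)c2cn[nH]c(=O)c12`: 12000 nM
Compound 2 `O=C1CCCN1c1cnc(NCc2c(F)ccc3c2CCO3)n2cnnc12`: 640000 nM
Compound 3 `Cc1ncccc1-c1cnc(NCc2c(F)ccc3c2CCO3)n2c(=O)[nH]nc12`: a limit of the assay, < 2000 nM

In a physicochemical assay for solubility, read by LC-MS, in phosphate buffer, with a stated time of 24 h, at pH 7.4 (on this read-out higher numbers stand for higher solubility and lower numbers for lower solubility), compound 2 holds the highest of the two numbers; the nearest, from compound 1, lies beyond the usual scatter below it. The value of compound 3 is a limit of this assay only (the limit of < 2000 nM in this assay, at which 1 of the 3 values shown sits). Compound 4 `COCCC(=O)Nc1cnc(NCc2c(F)ccc3c2CCO3)n2cnnc12` has not yet been measured; it differs from compound 2 in one place: ((2-methoxyethyl)carbonyl)amino in place of 2-oxopyrrolidin-1-yl on an aromatic carbon. Going by the values given here, both groups carry a carbonyl, and no measured pair shows this kind of exchange, so the step is expected to stay small, with a modest decrease at most. Compound 4 is thus estimated at 400000 nM (range 100000 nM to 1000000 nM), a step of a 1.6-fold lower number from compound 2 to compound 4 (0.20 log units; within the scatter).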

Compound 4, solubility: 980000 nM
Compound 4: the middle estimate sits 2.5-fold (0.39 log units) below what was measured; the range from low to high includes it.
By their numbers in this assay, from the lowest: compound 1; then compounds 2 and 4 (each within the scatter of the next). At a limit, below all of these: compound 3.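

In this assay, ((2-methoxyethyl)carbonyl)amino in place of 2-oxopyrrolidin-1-yl gives a 1.5-fold higher number from compound 2 to compound 4 (0.19 log units; within the scatter), so the two compounds cannot be told apart. At this aromatic carbon, then, the five-membered ring can give way to an open chain carrying a hydrogen-bond donor without separating the two numbers. Nothing shown here offers a cause for this step. On these data alone, whether a carboxylic acid, an amine or a longer chain at this aromatic carbon would leave the number equally undisturbed remains open. So does the effect of a methyl group on the amide nitrogen of compound 4.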